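Nitro in place of ethyl on the urea aryl ring

The source may report more compounds than this note shows. Statements on the series, on what has been measured and on what is new or still open speak of the compounds shown alone.

Going by the values given here, compound 2 `CCc1ccc(NC(=O)Nn2c(-c3ccccc3)nc3ccccc3c2=O)cc1` gives the higher of the two numbers so far in a functional assay on the whole organism (strain albino) with Mus musculus as the target, at a dose of 100 mg/kg by the intraperitoneal route (a lower number here means less inhibition, a higher number more inhibition at the dose given (going by the name of the read-out)), reading 61%, while compound 1 `O=C(Nc1ccccc1)Nn1c(-c2ccccc2)nc2ccccc2c1=O` reads 56% in this assay; the only step on record, a number 5 percentage points higher from compound 1 to compound 2 (within the scatter), lies within the scatter, so the two compounds cannot be ordered. Compound 3 `O=C(Nc1ccc([N+](=O)[O-])cc1)Nn1c(-c2ccccc2)nc2ccccc2c1=O` is not yet measured. Its change from compound 2 is nitro in place of ethyl on an aromatic carbon. Among the compounds with values here, no measured step bears on a nitro group; the single step on this aromatic carbon shows that an ethyl in place of hydrogen made no difference beyond the scatter, which gives no direction for compound 3. The expected step in this assay from compound 2 is therefore a number 6 percentage points lower from compound 2 to compound 3 (within the scatter), a change not expected to exceed the scatter. For compound 3 the estimated read-out in this assay is 55%, with a range from 35% to 75%.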

Compound 3, a percentage reported as inhibition, in the whole organism at one dose (the size of the read-out at that dose, not a potency): 42%
Compound 3: middle estimate off by 13 percentage points, on the high side, and the stated range covers the measured number.
By their numbers in this assay, from the lowest: compound 3; then compounds 1 and 2 (each within the scatter of the next).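

In this assay this aromatic carbon, para to a large group, now responds to what sits on it: nitro in place of ethyl gives a number 19 percentage points lower from compound 2 to compound 3 (beyond the scatter) and nitro in place of hydrogen gives a number 14 percentage points lower from compound 1 to compound 3 (beyond the scatter) on the same scaffold. Both steps run the same way, so the lower number holds against either neighbour in the series, whereas ethyl in place of hydrogen stayed within the scatter (a number 5 percentage points higher from compound 1 to compound 2 (within the scatter)). Nothing on record explains the drop.

Going by these compounds, only nitro has moved the number so far, so it remains open whether the drop is particular to nitro or shared by other groups on this carbon, such as an amine, a carboxylic acid or chlorine. The series also leaves open whether nitro lowers the number at other carbons of this ring.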